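The source may hold more compounds than are shown below. What is called first, only, known or untested is meant among the compounds shown, and "the series" means these compounds.

- compound 1 `CCCCc1nc(C)c(CC(=O)O)c(=O)n1Cc1ccc(-c2ccccc2-c2nnn[nH]2)cc1` gives 0.13 mg/kg
- compound 2 `CCCCc1nc(C)c(CCC(=O)N2CCSCC2)c(=O)n1Cc1ccc(-c2ccccc2-c2nnn[nH]2)cc1` gives 0.204 mg/kg

For the measured compounds named here, in an in vivo functional assay on the whole organism for inhibition, with Rattus norvegicus as the target (a lower number here means that less compound is needed, a higher number that more compound is needed for the effect), compound 2 gives 0.204 mg/kg and stands within the scatter of compound 1 at 0.13 mg/kg, the only other number available. Compound 3 `CCCCc1nc(C)c(CCC(=O)N2CCOCC2)c(=O)n1Cc1ccc(-c2ccccc2-c2nnn[nH]2)cc1` differs from compound 2 by morpholin-4-yl in place of thiomorpholin-4-yl on a carbonyl carbon, with morpholin-4-yl in place of thiomorpholin-4-yl on a carbonyl carbon. Going by the values given here, no measured step makes this exchange. Among the compounds with values here, the one measured step, a 1.6-fold higher number from compound 1 to compound 2 (0.20 log units; within the scatter), concerns a different change at the same chain and so bears on it only loosely. Resting on that step and on compound 2 at 0.204 mg/kg, the account expects no shift beyond the scatter in this assay. The expected size is a 1.0-fold lower number from compound 2 to compound 3 (0.01 log units; within the scatter) and its direction is left open. Compound 3 is estimated at 0.2 mg/kg, with an expected range from 0.08 mg/kg to 0.5 mg/kg.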

Compound 3, dose for half-maximal effect: 0.143 mg/kg
Beside the measured number, compound 3's estimate is 1.4-fold (0.15 log units) above it; measured number inside the range.
By their numbers in this assay, from the lowest: compounds 1, 3 and 2 (each within the scatter of the next).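

In this assay, morpholin-4-yl in place of thiomorpholin-4-yl on the carbonyl carbon gives a 1.4-fold lower number from compound 2 to compound 3 (0.15 log units; within the scatter), so the exchange of sulfur for oxygen in this ring does not separate the two amides at this position. The carboxy comparison now rests on a second ring amide, with a 1.1-fold higher number from compound 1 to compound 3 (0.04 log units; within the scatter), so both amides shown remain within the scatter of the acid. No measurement at hand explains these results.

From the compounds shown here alone, it remains open how a piperidin-1-yl ring or an open-chain dimethylamino group on the same carbonyl carbon would read in this assay. Also open, going by these compounds, is whether a piperazine ring there, or a longer chain between the carbonyl and the shared core, would move the dose beyond the scatter.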